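Sulfoxide to thioether in the long-chain pyridine series

A few compounds are considered here, and "the series" means these few. Any claim that something is new, unique, unknown or untested is made for them only; others in the source may bear on it.

Measured so far:
compound 1 `COc1ccc(CCCCCCCCOc2ccc(C[S+]([O-])c3cccc(C(=O)O)c3)nc2/C=C/C(=O)O)cc1` gives 3900 nM in a functional assay on the whole organism with Homo sapiens as the target, read by calcium flux; on this read-out higher numbers stand for weaker inhibition and lower numbers for stronger inhibition
compound 2 `COc1ccc(CCCCCCCCOc2ccc(CS(=O)(=O)Cc3cccc(C(=O)O)c3)nc2/C=C/C(=O)O)cc1` gives 920 nM
compound 3 `COc1ccc(CCCCCCCCOc2ccc(CSCc3cccc(C(=O)O)c3)nc2CCC(=O)O)cc1` gives 240 nM

Compound 1 stands with the highest number of the three. Compound 2 and compound 3 lie below it, compound 3 the furthest; both gaps lie beyond the scatter, so compound 1 is the weakest of the measured set. Compound 4 `COc1ccc(CCCCCCCCOc2ccc(CSCc3ccccc3C(=O)O)nc2/C=C/C(=O)O)cc1` is not yet measured. It differs from compound 1 as follows: a group of 11 heavy atoms (8 carbon, 2 oxygen, 1 sulfur; one six-membered aromatic ring of carbon only) in place of a group of 11 heavy atoms (7 carbon, 3 oxygen, 1 sulfur; one six-membered aromatic ring of carbon only), on a saturated chain carbon bound to an aromatic carbon. For the measured compounds named here, no step between measured compounds isolates this change, so the size of the move is uncertain; the lower numbers of compound 2 and compound 3 suggest a step downward. For compound 4 the expected step is a 6.5-fold lower number from compound 1 to compound 4 (0.81 log units; beyond the scatter), a move beyond the scatter. Compound 4 is estimated at 600 nM, within 120 nM to 3000 nM.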

Compound 4, half-maximal inhibitory concentration: 710 nM
Estimate against measurement, compound 4: 1.2-fold (0.07 log units) below; measured number inside the range.
By their numbers in this assay, from the lowest: compound 3; then compounds 4 and 2 (each within the scatter of the next); then compound 1.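

For the compounds shown here, at the saturated chain carbon bound to an aromatic carbon, replacing the sulfoxide-bearing group of compound 1 with (2-carboxybenzyl)sulfanyl gives the first readable step in this assay, a 5.5-fold lower number from compound 1 to compound 4 (0.74 log units; beyond the scatter), so this position tolerates change and the number responds to it. The swap alters the sulfur, the benzyl carbon and the place of the carboxylic acid together, and the step cannot be divided among them. No supporting measurement bears on its origin.

Which of these parts carries the step stays open. So does the effect of a tetrazole in place of the carboxylic acid on the benzyl ring.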